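This account rests on a few compounds, and the source may have more. Where it says the series, first, only, none or still open, it means among the compounds named here.

Measured so far in a functional assay on HEK293 cells for agonist activity at growth hormone secretagogue receptor type 1 (Homo sapiens), read by HTRF and inositol phosphate accumulation, with a stated time of 90 min, in the presence of a further agent that is not named here; on this read-out lower numbers stand for smaller maximal responses and higher numbers for larger maximal responses:

- compound 1, `Cc1ccc2[nH]c(C(=O)N[C@@H]3CCN(S(=O)(=O)c4ccccc4)C[C@@H]3C(=O)NCCN(C)C)cc2c1`, in this assay gives 93%
- compound 2, `Cc1ccc2[nH]c(C(=O)N[C@H]3CN(S(=O)(=O)c4ccccc4)C[C@@H]3C(=O)NC[C@H]3CCCN3)cc2c1`, in this assay gives 94%

The numbers of compound 1 and compound 2 lie within the usual scatter of each other, so the two cannot be ordered. Among the compounds with values here, both give a maximal response close to the reference, and no step between measured compounds is available for this series.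

Compound 3, `Cc1ccc2[nH]c(C(=O)N[C@H]3CN(S(=O)(=O)c4ccccc4)C[C@@H]3C(=O)N[C@@H]3CCCNC3)cc2c1`, is the next compound and remains to be measured in this assay. Against compound 2 it carries the same atoms joined differently: piperidin-3-yl in place of (pyrrolidin-2-yl)methyl on an amide-type nitrogen. Cut one bond further out, the change reads ((pyrrolidin-2-yl)methyl)amino to (piperidin-3-yl)amino on the carbamoyl.

Within the data shown here, with no measured step to lean on, the working expectation is no change beyond the scatter, since compound 2 already sits near a full response with 94%; the estimated step is a number 6 percentage points lower from compound 2 to compound 3 (within the scatter), with room for a moderate loss. Compound 3 is therefore expected to give 88%, in the range 65% to 100%.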

Compound 3, largest response reached (Emax), in percent of the reference or control that the assay uses: 91%
Estimate against measurement, compound 3: 3 percentage points below; measured number inside the range.
By their numbers in this assay, from the lowest: compounds 3, 1 and 2 (each within the scatter of the next).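

In this assay, within the data shown here, piperidin-3-yl in place of (pyrrolidin-2-yl)methyl on the amide-type nitrogen gives a number 3 percentage points lower from compound 2 to compound 3 (within the scatter) and so provides the first measured step at this position of the series. The two groups have the same atoms joined differently, and this change of ring size and attachment leaves no separable difference in maximal response. Nothing available bears on the reason for this result.

Open, on these data alone, is whether the maximal response at this position holds with a group that has no ring nitrogen, such as cyclohexyl, or with a carboxylic acid on the same amide-type nitrogen. Also open, as far as these compounds go, is how the mirror-image arrangement at the defined stereocentre of piperidin-3-yl would read, and whether the step seen here on a maximal response carries any meaning for potency, which this read-out does not give.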